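The compounds below may be only part of what the source reports. "The series", "measured", "known", "first", "only" and "open" are said of these compounds alone.

Values so far in a functional assay on Ramos cells (Homo sapiens) for antiproliferative activity; a higher number here means a weaker inhibitor, a lower number a stronger inhibitor:
- compound 1 `CC(C)(C)c1ccc(COc2ccc(-c3cn([C@H]4CCN(C[C@@H]5CO5)C4)c4ncnc(N)c34)cc2)cc1` gives 4210 nM
- compound 2 `Nc1ncnc2c1c(-c1ccc(Oc3ccccc3)cc1)cn2[C@H]1CCN(C[C@@H]2CO2)C1` gives 6710 nM

For the measured compounds named here, the only measured step is a 1.6-fold higher number from compound 1 to compound 2 (0.20 log units; within the scatter) and so compound 2 cannot be separated from compound 1 on these numbers.

Compound 3 `Nc1ncnc2c1c(-c1ccc(Oc3ccccc3)cc1)cn2[C@H]1CCN(C[C@H]2CO2)C1` is the next to be read against compound 2. The change is the two compounds have the same atoms and bonds and differ only in configuration as drawn: 1 of 2 stereo elements differ; a stereocentre at a saturated ring carbon is drawn R in compound 2 and S in compound 3 (a stereocentre at a saturated ring carbon is drawn R in compound 2 and S in compound 3). Going by the values given here, the one measured step concerns the group on the oxygen, leaving this stereocentre unchanged, so no measured pair tests the configuration directly. An estimated step of a 1.1-fold lower number from compound 2 to compound 3 (0.05 log units; within the scatter) is expected in this assay with no shift beyond the scatter and no favoured direction. For compound 3 the estimated value is 6000 nM (2500 nM to 15000 nM) with the range kept wide for that reason.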

Compound 3, half-maximal inhibitory concentration: > 50000 nM
Compound 3 gave a limit, no number (the forecaster's own chance of this, stated with the estimate: 10%); middle value at least 8.3-fold (0.92 log units) away from the limit.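

Inverting the stereocentre at a saturated ring carbon from R to S in this assay gives an at least 7.4-fold higher number from compound 2 to compound 3 (0.87 log units; beyond the scatter), the only step shown that lies beyond the scatter. Compound 3 gives a limit, not a number: the limit of > 50000 nM in this assay, at which 1 of the 3 values shown sits. The step is therefore a minimum, and configuration at this one centre is the whole of the change behind it: the fact that compounds 2 and 3 differ only in the configuration as drawn

Going by these compounds, whether the same dependence on configuration holds with the 4-(tert-butyl)benzyl group of compound 1 remains open, as does the effect of the second stereo element, which is the same in compound 2 and compound 3. Also open, on these data alone, is how either configuration compares with an acrylamide in place of the group that carries this stereocentre.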